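Chloro-to-hydrogen step on the bicyclic core of compound 2

The source may hold more compounds than are shown below. What is called first, only, known or untested is meant among the compounds shown, and "the series" means these compounds.

Measured so far:
- compound 1, `ClCc1ccc(Cn2cnc3c(Cl)ncnc32)cc1`: 2880 nM
- compound 2, `ClCc1ccccc1Cn1cnc2nc(Cl)nc(Cl)c21`: 24500 nM

Of the compounds shown here, two have been measured in a functional assay on SF-268 cells (Homo sapiens) for cytotoxicity, read by sulforhodamine B assay, with a stated time of 48 h; on this read-out lower numbers stand for stronger inhibition of growth and higher numbers for weaker inhibition of growth. Compound 1 gives 2880 nM. Compound 2 gives 24500 nM and stands at the highest of the two numbers; the gap to compound 1 lies beyond the scatter. The two differ in more than one place, so their values are recorded side by side without reading them as a single step.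

The next compound, compound 3, `ClCc1ccccc1Cn1cnc2ncnc(Cl)c21`, is compound 2 with one change: hydrogen in place of chloro on an aromatic carbon. The change takes place on the core of compound 2, on the aromatic carbon between two ring nitrogen atoms. After the change compound 3 carries the same core as compound 1, but with the chloromethylbenzyl group attached in a different pattern, so no measured step covers the change directly.

Expectation in this assay: a move toward lower numbers, of a size that reaches beyond the scatter, is expected, since the core of compound 3 is also the core of compound 1, and compound 1 gives 2880 nM. The expected step is a 2.7-fold lower number from compound 2 to compound 3 (0.43 log units; beyond the scatter). Compound 3 is estimated at 9000 nM, with a range of 3000 nM to 27000 nM.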

Compound 3, concentration for total growth inhibition: 24500 nM
Estimate against measurement, compound 3: 2.7-fold (0.43 log units) below; the range from low to high includes it.
By their numbers in this assay, from the lowest: compound 1; then compounds 2 and 3 (each within the scatter of the next).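

In this assay, hydrogen can replace chloro on the aromatic carbon between two ring nitrogen atoms with no change at the digits printed from compound 2 to compound 3 (within the scatter), so this chloro group is dispensable for the growth-inhibition read-out in the series carrying the chloromethylbenzyl group as attached in compound 2. The earlier gap between compounds 1 and 2 could not be read as a single step, but compound 3 now carries the core of compound 1 and still stands apart from it: compound 1 gives 2880 nM and compound 3 gives 24500 nM in this assay, leaving the attachment pattern of the chloromethylbenzyl group as the remaining structural difference between the two. Nothing at hand on the mechanism of these cells' response bears on why the chloro group can be lost without a shift in the number.

From the compounds shown here alone, whether an amine or a methoxy group on the same aromatic carbon would behave like hydrogen and chloro remains open. Also open, going by these compounds, is what replacing the chloromethyl group with a hydroxymethyl group, or the remaining chloro group on the core with an amine, would do to the number.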